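Trading the Nitrile for a Carboxylic Acid

The source may report more compounds than this note shows. Statements on the series, on what has been measured and on what is new or still open speak of the compounds shown alone.

Compound 1 `CCn1c(C(=O)NCCN(C)C)ccc1C(CC)(CC)c1ccc(OCCC(O)(CC)CC)c(C)c1`: 430 nM
Compound 2 `CCn1c(C(=O)NCC#N)ccc1C(CC)(CC)c1ccc(OCCC(O)(CC)CC)c(C)c1`: > 50000 nM
Compound 3 `CCn1c(C(=O)Nc2cccc(C(F)(F)F)c2)ccc1C(CC)(CC)c1ccc(OCCC(O)(CC)CC)c(C)c1`: > 50000 nM

Three compounds share one core and differ only in the group on the amide-type nitrogen. In a functional assay on MCF7 cells (Homo sapiens) for antiproliferative activity, read by MTT assay, with a stated time of 48 h (a lower number here means a stronger inhibitor, a higher number a weaker inhibitor), compound 1 gives 430 nM. Compound 2 reaches only the limit of this assay, > 50000 nM. Compound 3 likewise reaches only a limit, > 50000 nM. Compound 2 therefore stands at the limit of > 50000 nM in this assay, at which 2 of the 3 values shown sit, and the step from it cannot be sized against compound 3: a step that the two limits leave unreadable from compound 2 to compound 3.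

The next compound, compound 4 `CCC(C)C(NC(=O)c1ccc(C(CC)(CC)c2ccc(OCCC(O)(CC)CC)c(C)c2)n1CC)C(=O)O`, changes compound 2 at that same nitrogen: 1-carboxy-2-methylbutyl in place of cyanomethyl on an amide-type nitrogen.

Going by the values given here, two measured steps bear on this place. Leaving the 2-(dimethylamino)ethyl group of compound 1 cost heavily in both directions tried: an at least 110-fold higher number from compound 1 to compound 2 (2.06 log units; beyond the scatter) and an at least 110-fold higher number from compound 1 to compound 3 (2.06 log units; beyond the scatter). Neither step tells how a carboxylic acid on that chain will fare, and no other value does. Among the compounds with values here, the only compound with a strong number carries a basic amine, which compound 4 lacks. The step from compound 2 is expected to be small or not readable: an at least 1.6-fold lower number from compound 2 to compound 4 (0.22 log units; that floor lies within the scatter). Compound 4 is therefore estimated at 30000 nM, within 5000 nM to 100000 nM.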

Compound 4, half-maximal inhibitory concentration: 11300 nM
Estimate against measurement, compound 4: 2.7-fold (0.42 log units) above, within the range that was stated.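

Going by these compounds alone, this position can hold something other than 2-(dimethylamino)ethyl and still give a number: in this assay compound 4 gives 11300 nM, the only value shown for a compound without that group. The 1-carboxy-2-methylbutyl group therefore separates from both other replacements, with an at least 4.4-fold lower number from compound 2 to compound 4 (0.64 log units; beyond the scatter) and an at least 4.4-fold lower number from compound 3 to compound 4 (0.64 log units; beyond the scatter), so leaving 2-(dimethylamino)ethyl does not always end at the limit, although the gain stops well short of compound 1, as a 26-fold higher number from compound 1 to compound 4 (1.42 log units; beyond the scatter) shows. Compound 2 itself remains a limit and not a number, so its step to compound 4 has a floor but no full size: the limit of > 50000 nM in this assay, at which 2 of the 4 values shown sit.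

The change from cyanomethyl brings a carboxylic acid and a longer branched chain in one move, and the compounds shown do not separate what each part contributes. As far as these compounds go, how a carboxylic acid on a short unbranched chain would fare stays open, as does whether a dimethylamino group on the same branched chain would come closer to compound 1.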